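Compound 3: Hydrogen in Place of Chloro

The source may hold more compounds than are shown below. What is called first, only, known or untested is meant among the compounds shown, and "the series" means these compounds.

Among the measured compounds shown here, in a functional assay on HepG2 cells (Mus musculus) for antiproliferative activity against HepG2 (Homo sapiens), read by MTT assay, with a stated time of 48 h (on this read-out lower numbers stand for stronger inhibition and higher numbers for weaker inhibition), compound 1 (`COc1cc(/C=C/c2nnc(NC(=O)c3ccccc3Br)s2)c(Br)c(OC)c1OC`) gives 250 nM and compound 2 (`COc1cc(/C=C/c2nnc(NC(=O)c3ccc(Cl)cc3)s2)c(Br)c(OC)c1OC`) gives 180 nM, so compound 2 stands within the scatter of its only measured neighbour. Compound 3 (`COc1cc(/C=C/c2nnc(NC(=O)c3ccccc3)s2)c(Br)c(OC)c1OC`) carries hydrogen in place of chloro on an aromatic carbon, turning 4-chlorophenyl into phenyl (hydrogen in place of chloro on an aromatic carbon). For the measured compounds named here, one measured step touches this part of the structure (a 1.4-fold lower number from compound 1 to compound 2 (0.14 log units; within the scatter)), and it stayed within the scatter. Compound 1 and compound 2 both carry a halogen on that ring, so the data hold no direct case of the unsubstituted phenyl. Given the small size of the step to compound 2 (a 1.4-fold lower number from compound 1 to compound 2 (0.14 log units; within the scatter)), no change beyond the scatter is expected in this assay in either direction. The expected step (a 1.4-fold higher number from compound 2 to compound 3 (0.14 log units; within the scatter)) is estimated to remain within the scatter. For compound 3 the estimated value is 250 nM, with an expected range from 100 nM to 600 nM in repeated measurements.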

Compound 3, half-maximal inhibitory concentration: 180 nM
Estimate against measurement, compound 3: 1.4-fold (0.14 log units) above, within the range that was stated.
By their numbers in this assay, from the lowest: compounds 2, 3 and 1 (each within the scatter of the next).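

With the unsubstituted phenyl now in hand, this assay gives a direct reading of what a halogen on this ring contributes: hydrogen in place of chloro gives no change at the digits printed from compound 2 to compound 3 (within the scatter), and hydrogen in place of bromo gives a 1.4-fold lower number from compound 1 to compound 3 (0.14 log units; within the scatter). Neither the chloro, para to a large group, nor the bromo is therefore shown to be needed for a number in this range, and the three compounds cannot be separated by this ring's substituent. No measurement on hand offers an explanation for this.

The compounds shown compare only hydrogen, chloro and bromo on this ring. As far as these compounds go, whether an amine, a carboxylic acid or a longer chain here would move the number beyond the scatter stays open.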